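Extending the acid-bearing amide side chain

This account rests on a few compounds, and the source may have more. Where it says the series, first, only, none or still open, it means among the compounds named here.

The series shares one core and differs only in the group on the amide nitrogen. Compound 1 `CCn1c(C(=O)N[C@@H](C)CO)ccc1C(CC)(CC)c1ccc(OCS(=O)(=O)c2ccccc2)c(C)c1` carries the hydroxymethyl variant, and in a functional assay on PC-3 cells (Homo sapiens) for antiproliferative activity, read by MTT assay, with a stated time of 24 h (on this read-out lower numbers stand for stronger inhibition and higher numbers for weaker inhibition), compound 1 gives 9520 nM. Compound 2 `CCn1c(C(=O)N[C@H](CO)CCCO)ccc1C(CC)(CC)c1ccc(OCS(=O)(=O)c2ccccc2)c(C)c1` gives 6810 nM, and compound 3 `CCn1c(C(=O)N[C@@H](C)C(=O)O)ccc1C(CC)(CC)c1ccc(OCS(=O)(=O)c2ccccc2)c(C)c1` gives 16800 nM. Among these three numbers compound 3 stands highest; its nearest neighbour is compound 1, with a 1.8-fold higher number from compound 1 to compound 3 (0.25 log units; within the scatter), and its furthest is compound 2, with a 2.5-fold higher number from compound 2 to compound 3 (0.39 log units; beyond the scatter).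

Compound 4 `CCn1c(C(=O)N[C@H](CCC(=O)O)C(=O)O)ccc1C(CC)(CC)c1ccc(OCS(=O)(=O)c2ccccc2)c(C)c1` is the next step from compound 3: 1,3-dicarboxypropyl in place of 1-carboxyethyl on an amide-type nitrogen. Two of the measured steps bear on it. The step of a 1.8-fold higher number from compound 1 to compound 3 (0.25 log units; within the scatter) shows that a carboxy in place of hydroxymethyl went with a higher number, though within the scatter; the step of a 2.5-fold higher number from compound 2 to compound 3 (0.39 log units; beyond the scatter) shows that the larger group on the amide nitrogen went with the lower number. Compound 4 both adds a second carboxy and lengthens the chain, so the two precedents pull in opposite directions, and neither is large. The step is therefore expected to be small, leaning toward a higher number: a 1.3-fold higher number from compound 3 to compound 4 (0.12 log units; within the scatter). Compound 4 is expected to give 22000 nM, with a range from 9000 nM to 55000 nM.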

Compound 4, half-maximal inhibitory concentration: > 50000 nM
Compound 4: only a limit was reported; the forecaster's own chance of this, stated with the estimate: 15%; middle value at least 2.2-fold (0.35 log units) from the limit.
By their numbers in this assay, from the lowest: compounds 2, 1 and 3 (each within the scatter of the next, the first and the last beyond it). At a limit, above all of these: compound 4.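

For the compounds shown here, on the amide nitrogen, 1,3-dicarboxypropyl in place of 1-carboxyethyl gives an at least 2.9-fold higher number from compound 3 to compound 4 (0.47 log units; beyond the scatter), and this is the first change to carry activity past what this assay could put a number on. The group of compound 2 holds the same count of carbon atoms as that of compound 4 and differs in its oxygen atoms, yet the change reads an at least 7.3-fold higher number from compound 2 to compound 4 (0.86 log units; beyond the scatter), and from the shorter hydroxymethyl-bearing group it reads an at least 5.2-fold higher number from compound 1 to compound 4 (0.72 log units; beyond the scatter), so in this pair size of the carbon chain alone does not go with the loss, while the second carboxy group does. Compound 4 carries a limit of the assay rather than a number, and each of these steps gives only the least possible size: the limit of > 50000 nM in this assay, at which 1 of the 4 values shown sits.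

As far as these compounds go, how far compound 4 lies past that limit stays open, and so does the share of the step that belongs to the second carboxy group rather than to its placement on the longer chain. Also open, from the compounds shown here alone, is how the same chain would read with a single carboxylic acid, an ester or an amine at its end.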